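This account rests on a few compounds, and the source may have more. Where it says the series, first, only, none or still open, it means among the compounds named here.

Measured in a functional assay on HuCC-A1 cells (Homo sapiens) for cytotoxicity, read by MTT assay, with a stated time of 48 h; on this read-out lower numbers stand for stronger inhibition and higher numbers for weaker inhibition:
compound 1 `COc1ccc(/C=C/C(=O)c2cccc(-n3cc(COc4ccc5ccc(=O)oc5c4)nn3)c2)cc1OC`: 33400 nM
compound 2 `COc1cccc(/C=C/C(=O)c2cccc(-n3cc(COc4ccc5ccc(=O)oc5c4)nn3)c2)c1OC`: 11100 nM
compound 3 `COc1cccc(/C=C/C(=O)c2ccc(-n3cc(COc4ccc5ccc(=O)oc5c4)nn3)cc2)c1OC`: 4810 nM

In this assay, compound 1 has the highest number of the series at 33400 nM, and its gaps to both other compounds lie beyond the scatter. Compound 4 `COc1ccc(/C=C/C(=O)c2cccc(-n3cc(COc4cc(=O)oc5ccccc45)nn3)c2)cc1OC` has the same atoms as compound 1, joined differently: a group of 11 heavy atoms (9 carbon, 2 oxygen; one six-membered aromatic ring of carbon only, one six-membered aromatic ring with 1 hetero atom) in place of a group of 11 heavy atoms (9 carbon, 2 oxygen; one six-membered aromatic ring of carbon only, one six-membered aromatic ring with 1 hetero atom), on an oxygen on a saturated carbon. The two groups carry the same counts, and the rest of the molecule is unchanged.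

Going by the values given here, no measured step touches this place. Among the compounds with values here, the only step available, a 3.0-fold lower number from compound 1 to compound 2 (0.48 log units; beyond the scatter), is a modest one, but it concerns the dimethoxyphenyl group and bears on the present change only indirectly, as a rough guide to how far a rearrangement of the same atoms can move the number. The data do not show the direction of the present change. Since compound 1 already has the highest number at 33400 nM, a modest shift toward lower numbers seems somewhat more likely than a rise, though a result within the scatter would not be surprising. The expected change is a 1.7-fold lower number from compound 1 to compound 4 (0.22 log units; within the scatter), and this estimate is uncertain. For compound 4 the estimated value is 20000 nM, with an expected range from 7000 nM to 60000 nM.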

Compound 4, half-maximal inhibitory concentration: 38600 nM
The estimate for compound 4 lay 1.9-fold (0.29 log units) below the measured number, within the range that was stated.
By their numbers in this assay, from the lowest: compound 3; then compound 2; then compounds 1 and 4 (each within the scatter of the next).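

In this assay, exchanging one group for another with the same atom counts, on an oxygen on a saturated carbon, gives a 1.2-fold higher number from compound 1 to compound 4 (0.06 log units; within the scatter), so the two compounds cannot be told apart at this place. Going by these compounds alone, the earlier compounds showed only that rearranging the dimethoxyphenyl group can move the number, with a 3.0-fold lower number from compound 1 to compound 2 (0.48 log units; beyond the scatter), whereas this result shows that a rearrangement of the same atoms need not do so, at least for this one pair of groups carried with the 3,4-dimethoxyphenyl group. Nothing measured here explains why the two groups read alike.

As far as these compounds go, it remains open whether the same exchange would also stay within the scatter alongside the 2,3-dimethoxyphenyl group of compound 2, or in the arrangement of compound 3, which has the lowest number of the series. Also open, from the compounds shown here alone, is what a different kind of group on this oxygen would give, such as an amine, a carboxylic acid or a longer chain in place of these two groups.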